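Adding a Benzoyl Group to a Ring Nitrogen

This account rests on a few compounds, and the source may have more. Where it says the series, first, only, none or still open, it means among the compounds named here.

Measured compounds:
- compound 1, `O=C(Nc1ccccc1O)C1CCc2ccccc2N1C(=O)c1ccccc1Cl`: 47400 nM
- compound 2, `CCCC(=O)N1c2ccccc2CCC1C(=O)Nc1ccccc1C(F)(F)F`: > 70000 nM
- compound 3, `O=C(Nc1ccccc1C(F)(F)F)C1CCc2ccccc2N1`: 45500 nM

In a functional assay on MDA-MB-231 cells (Homo sapiens) for cytotoxicity, read by sulforhodamine B assay, with a stated time of 72 h (on this read-out higher numbers stand for weaker inhibition of growth and lower numbers for stronger inhibition of growth), compound 3 gives 45500 nM, the lower of the two plain numbers, with compound 1 sitting within the scatter of it, so the two cannot be ranked. For compound 2 the assay reports only a limit, > 70000 nM, not a number.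

Compound 4, `O=C(Nc1ccccc1C(F)(F)F)C1CCc2ccccc2N1C(=O)c1ccccc1`, differs from compound 3 by benzoyl in place of hydrogen on a nitrogen on an aromatic ring in a ring. For the measured compounds named here, one measured step bears on this change: an at least 1.5-fold lower number from compound 2 to compound 3 (0.18 log units; that floor lies within the scatter), where removing an acyl group from the same nitrogen gave a number at least somewhat lower, though at its floor that difference lies within the scatter, and the step rests on a limit, (the limit of > 70000 nM in this assay, at which 1 of the 3 values shown sits). Putting an acyl group back onto that nitrogen is therefore expected to raise the number in this assay modestly, if at all, with a real chance that only a limit is reported. The step from compound 3 to compound 4 is expected to be a 1.3-fold higher number from compound 3 to compound 4 (0.12 log units; within the scatter).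

Compound 4 is estimated at 60000 nM, within a range of 25000 nM to 150000 nM.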

Compound 4, concentration for 50% growth inhibition: 5290 nM
Beside the measured number, compound 4's estimate is 11-fold (1.05 log units) above it, outside the stated range (below it).
By their numbers in this assay, from the lowest: compound 4; then compounds 3 and 1 (each within the scatter of the next). At a limit, above all of these: compound 2.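

The nitrogen on an aromatic ring in a ring can carry an acyl group with a clear gain in growth inhibition, as benzoyl in place of hydrogen in this assay gives an 8.6-fold lower number from compound 3 to compound 4 (0.93 log units; beyond the scatter). The group on that carbonyl carbon also counts, as phenyl in place of propyl gives an at least 13-fold lower number from compound 2 to compound 4 (1.12 log units; beyond the scatter). That second step rests on compound 2, which is reported only as a limit: the limit of > 70000 nM in this assay, at which 1 of the 4 values shown sits.

Going by these compounds, whether the aromatic ring of benzoyl is what counts stays open, and a cyclohexylcarbonyl group or a longer chain such as hexanoyl on the same nitrogen would help to separate ring from size. Compound 1 also carries a substituted benzoyl group there but differs from compound 4 in more than one place, so the compounds shown cannot say whether the gain holds with another group on the amide nitrogen.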